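This account rests on a few compounds, and the source may have more. Where it says the series, first, only, none or still open, it means among the compounds named here.

In a functional assay on SK-MEL-2 cells (Homo sapiens) for cytotoxicity (on this read-out lower numbers stand for stronger inhibition and higher numbers for weaker inhibition), compound 1 (`Cc1ccc(C2CN(S(=O)(=O)c3ccccc3)C(=O)N2)cc1`) returns only a limit and not a number, > 316000 nM. Within the data shown here, compound 2 (`O=C1NC(c2ccc(Br)cc2)CN1S(=O)(=O)c1ccc2c(c1)CCC2`) gives a measured value in the same test, 32600 nM, and this is the only true number available so far. The two compounds differ in more than one place, so their results do not isolate the effect of any single change.

Compound 3 (`O=C1NC(c2ccc(Cl)cc2)CN1S(=O)(=O)c1ccc2c(c1)CCC2`) keeps the structure of compound 2 apart from one substitution, chloro in place of bromo on an aromatic carbon, para to a large group: chloro in place of bromo on an aromatic carbon. In other words, 4-bromophenyl becomes 4-chlorophenyl. Among the measured compounds shown here, no measured pair shows this swap, so the expectation is anchored on compound 2 and its value of 32600 nM. Given so small a substitution, no shift beyond the usual scatter of this assay is expected in either direction. The expected step, a 1.1-fold higher number from compound 2 to compound 3 (0.03 log units; within the scatter), is therefore small. For compound 3, the estimated value is 35000 nM, with an expected range from 12000 nM to 100000 nM.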

Compound 3, half-maximal inhibitory concentration: 64300 nM
Compound 3: the middle estimate sits 1.8-fold (0.26 log units) below what was measured; low and high end bracket the measured number.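

Chloro in place of bromo, on an aromatic carbon para to a large group, is the first single change that can be read in this assay, and it comes to a 2.0-fold higher number from compound 2 to compound 3 (0.29 log units; within the scatter). Compound 2 and compound 3 both give true numbers, so this swap can be read directly, and at this place the two halogens cannot be told apart in this assay. Compound 1 remains a limit and not a number: the limit of > 316000 nM in this assay, at which 1 of the 3 values shown sits.

The compounds shown leave open whether a group of another kind at this place, such as a methoxy group, an amine or a carboxylic acid, would move the number beyond the scatter, as the one pair covers only bromo and chloro. Among these compounds, also open is what the sulfonyl side of the molecule contributes: compound 1 differs from compound 2 and from compound 3 in more than one place, and no single-change pair yet isolates that part.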